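Methylsulfanyl for Fluoro on a Urea Scaffold

This account rests on a few compounds, and the source may have more. Where it says the series, first, only, none or still open, it means among the compounds named here.

Measured compounds:
compound 1 `COc1ccc(NC(=O)Nc2cc(C)nc3ccccc23)cc1` — 787 10^-6 cm/s
compound 2 `Cc1ccc(NC(=O)Nc2cc(C)nc3ccccc23)cc1` — 669 10^-6 cm/s
compound 3 `Cc1cc(NC(=O)Nc2ccc(F)cc2)c2ccccc2n1` — 801 10^-6 cm/s

All three were run in an ADME assay for permeability, using PAMPA, at pH 7.4; a higher number here means that the compound crosses the layer faster, a lower number that the compound crosses the layer more slowly. Among the compounds with values here, compound 3 stands with the other two inside a narrow band: the steps of a 1.0-fold higher number from compound 1 to compound 3 (0.01 log units; within the scatter) and a 1.2-fold higher number from compound 2 to compound 3 (0.08 log units; within the scatter) are both within the scatter, as is a 1.2-fold lower number from compound 1 to compound 2 (0.07 log units; within the scatter), so no compound of the three can be set apart from the others on these numbers.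

Compound 4 `CSc1ccc(NC(=O)Nc2cc(C)nc3ccccc23)cc1` differs from compound 3 by methylsulfanyl in place of fluoro on an aromatic carbon. The change again exchanges one small group for another on the same aromatic carbon, as in the three measured steps, and each of those exchanges — methoxy to methyl, methoxy to fluoro, methyl to fluoro — left the number where it was. Within the data shown here, no measured step involves methylsulfanyl, so nothing beyond this shared-position behaviour can be drawn on. Compound 4 is therefore expected to show a 1.1-fold lower number from compound 3 to compound 4 (0.03 log units; within the scatter), a step not beyond the scatter. Compound 4 is estimated at 750 10^-6 cm/s, in a range from 450 10^-6 cm/s to 1200 10^-6 cm/s.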

Compound 4, apparent permeability: 473 10^-6 cm/s
Beside the measured number, compound 4's estimate is 1.6-fold (0.20 log units) above it; the measured number falls inside the stated range.
By their numbers in this assay, from the lowest: compounds 4, 2, 1 and 3 (each within the scatter of the next).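

In this assay, within the data shown here, methylsulfanyl is the only sulfur-bearing group among the four on this aromatic carbon, para to a large group, and the steps of a 1.7-fold lower number from compound 3 to compound 4 (0.23 log units; within the scatter) and a 1.4-fold lower number from compound 2 to compound 4 (0.15 log units; within the scatter) and a 1.7-fold lower number from compound 1 to compound 4 (0.22 log units; within the scatter) all lie within the scatter. Among these compounds, these steps are larger than the three among the earlier compounds, yet none passes the scatter, so the four groups cannot be told apart at this position on these numbers. Nothing available accounts for the size of these steps.

The compounds shown leave open whether the position stays as undemanding with a group of another kind, such as an amine or a carboxylic acid, or with a longer chain such as ethylsulfanyl. They also leave open whether the same holds for changes elsewhere on the shared core.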